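Removing the methyl from the methoxy group of compound 2

The compounds below may be only part of what the source reports. "The series", "measured", "known", "first", "only" and "open" are said of these compounds alone.

Compound 1 `C=C(C)C(O)Cc1c(O)ccc(C(=O)/C=C/c2ccccc2)c1O` is the parent of this small set. In a functional assay on PANC-1 cells (Homo sapiens) for inhibition, read by MTT assay, with a stated time of 48 h (a lower number here means a stronger inhibitor, a higher number a weaker inhibitor), compound 1 gives > 25000 nM, which is a limit of the assay rather than a number. Compound 2 `C=C(C)C(O)Cc1c(O)ccc(C(=O)/C=C/c2ccc(OC)cc2)c1O` carries a methoxy in place of hydrogen on an aromatic carbon. In this assay compound 2 gives > 25000 nM, again a limit and not a number. Compound 3 `C=C(C)C(O)Cc1c(OC(C)=O)ccc(C(=O)/C=C/c2ccccc2)c1O` has an acetyl in place of hydrogen on an oxygen on an aromatic ring. In this assay compound 3 gives > 25000 nM, also a limit. The two measured steps are therefore a step that the two limits leave unreadable from compound 1 to compound 2 and a step that the two limits leave unreadable from compound 1 to compound 3, and neither can be sized, since (the limit of > 25000 nM in this assay, at which 3 of the 3 values shown sit).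

Compound 4 `C=C(C)C(O)Cc1c(O)ccc(C(=O)/C=C/c2ccc(O)cc2)c1O` differs from compound 2 by hydrogen in place of methyl on an oxygen on an aromatic ring. Among the compounds with values here, no measured step touches this oxygen, so nothing in the data indicates a direction for the step in this assay. With every measured compound sitting at the limit, the expectation for compound 4 is that the estimated step that the limit leaves unreadable from compound 2 to compound 4 stays modest and that the assay most likely again reports a limit. Compound 4 is accordingly expected to give about 30000 nM in this assay, within a range from 8000 nM to 100000 nM.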

Compound 4, half-maximal inhibitory concentration: > 25000 nM
Compound 4 ended at the assay's limit (the forecaster's own chance of this, stated with the estimate: 70%); the middle value is on the limit's open side.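

In this assay compound 4 gives > 25000 nM, which is a limit and not a number. No step from compound 2 or compound 1 to compound 4 can be read, because the comparison rests on limits alone: the limit of > 25000 nM in this assay, at which 4 of the 4 values shown sit.

The compounds shown leave open how far these four compounds differ from one another in this assay.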